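The source may hold more compounds than are shown below. What is called first, only, known or untested is meant among the compounds shown, and "the series" means these compounds.

Measured so far in an ADME assay on L02 cells (Homo sapiens) for cytotoxicity, read by MTT assay, with a stated time of 72 h; on this read-out lower numbers stand for stronger inhibition and higher numbers for weaker inhibition:
compound 1 `COc1ccc(-c2nnc(-c3nn(C)c4ccccc34)o2)cc1`: > 100000 nM.
compound 2 `Cn1nc(-c2nnc(-c3cccc(Cl)c3)o2)c2ccccc21`: > 100000 nM.

For compound 1 the figure of > 100000 nM is a limit of the assay, not a number. For compound 2 the figure of > 100000 nM is likewise a limit and not a number. Compound 2 therefore stands at the limit of > 100000 nM in this assay, at which 2 of the 2 values shown sit, with no value of the other compound falling beneath it; nothing in these two figures separates compound 1 from compound 2.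

Compound 3 `Cn1nc(-c2nnc(-c3ccc(O)cc3)o2)c2ccccc21` has not yet been measured. It differs from compound 2 by 4-hydroxyphenyl in place of 3-chlorophenyl on an aromatic carbon. For the measured compounds named here, no step between measured compounds shows how a change of this kind moves the read-out. The step from compound 2 to compound 3 is expected to be a number no higher from compound 2 to compound 3 (the limit leaves the size open), that is none beyond the scatter. Compound 3 is thus expected to give about 100000 nM, most likely reported again as a limit, within a range of 50000 nM to 200000 nM.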

Compound 3, half-maximal inhibitory concentration: > 100000 nM
Compound 3 gave a limit, no number; the forecaster's own chance of this, stated with the estimate: 80%; the middle value lies on the limit itself.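

In this assay compound 3 gives > 100000 nM as a limit of the assay and not a number. For the compounds shown here, no step from compound 1 or compound 2 to compound 3 can be read: the limit of > 100000 nM in this assay, at which 3 of the 3 values shown sit. The compounds shown leave open whether 4-hydroxyphenyl in place of 3-chlorophenyl moves the read-out at all.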